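Benzyl substituent exchange on the shared core

The source may hold more compounds than are shown below. What is called first, only, known or untested is meant among the compounds shown, and "the series" means these compounds.

Among the compounds with values here, compound 2 `Cc1cccc(CNc2nc3c(N)ncnc3n2[C@@H]2O[C@H](CO)[C@@H](O)[C@H]2O)c1` is the one member of this set for which an assay on COS-7 cells for inhibition of sodium/nucleoside cotransporter 2 (Homo sapiens), read by scintillation counting, in the presence of a further agent that is not named here (a higher number here means a weaker inhibitor, a lower number a stronger inhibitor), returns a number: compound 2 gives 19000 nM. Compound 1 `CCNC(=O)OC[C@H]1O[C@@H](n2cnc3c(N)ncnc32)[C@H](O)[C@@H]1O` reaches only a limit of the assay, as compound 1 gives > 100000 nM in this assay. Compound 3 `CC(=O)OC[C@H]1O[C@@H](n2cnc3c(N)ncnc32)[C@H](O)[C@@H]1O` likewise reaches only a limit, with compound 3 giving > 100000 nM in this assay. Within the data shown here, the single one-place step in hand, a step that the two limits leave unreadable from compound 1 to compound 3, cannot be read because both of its ends sit at the limit of > 100000 nM in this assay, at which 2 of the 3 values shown sit. Compound 2 thus stands alone as the only number shown, the other two values being limits.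

Compound 4 `Nc1ncnc2c1nc(NCc1ccc(Cl)cc1)n2[C@@H]1O[C@H](CO)[C@@H](O)[C@H]1O` differs from compound 2 in one place: 4-chlorophenyl in place of 3-methylphenyl on a saturated chain carbon bound to a nitrogen on an aromatic ring. Among the measured compounds shown here, no measured step bears on this part of the molecule; the one step available concerns a carbonyl substituent and is unreadable, so it gives no size to carry over. For compound 4 in this assay no step beyond the scatter is therefore expected in either direction. Compound 4 is expected to give 19000 nM, in the range 6000 nM to 60000 nM. The step this estimate implies, no change at the digits printed from compound 2 to compound 4 (within the scatter), is expected to lie within the scatter of repeated measurements.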

Compound 4, half-maximal inhibitory concentration: 11000 nM
Beside the measured number, compound 4's estimate is 1.7-fold (0.24 log units) above it, and the stated range covers the measured number.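

In this assay, the exchange of 3-methylphenyl for 4-chlorophenyl on a saturated chain carbon bound to a nitrogen on an aromatic ring gives the series its first readable step: a 1.7-fold lower number from compound 2 to compound 4 (0.24 log units; within the scatter). For this one pair, the 3-methylbenzyl and 4-chlorobenzyl groups therefore read alike at this place, and compound 4 joins compound 2 as a second number rather than a limit of the assay. Within the data shown here, the earlier compounds could not show this, as their only one-place step cannot be read and it concerns a carbonyl substituent elsewhere on the molecule, while limits still remain in the set: the limit of > 100000 nM in this assay, at which 2 of the 4 values shown sit.

Still open, on these data alone, is how this place responds to anything further from these two benzyl groups, such as a longer chain ending in phenyl or a benzyl group carrying a carboxylic acid or an amine on its ring. Also open, as far as these compounds go, is any link between the two benzylamino compounds and the carbonyl compounds, since compound 1 and compound 3 differ from compound 2 in more than one place.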